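The source may hold more compounds than are shown below. What is called first, only, known or untested is meant among the compounds shown, and "the series" means these compounds.

In a functional assay on MCF7 cells (Homo sapiens) for antiproliferative activity, read by MTT assay, with a stated time of 48 h (a higher number here means a weaker inhibitor, a lower number a stronger inhibitor), three compounds have been measured:

compound 1, `Cc1ccc2[nH]c(-c3cn(-c4ccccc4)nc3-c3ccc(F)cc3)nc2c1`, gives 1120 nM;
compound 2, `Fc1ccc(-c2nn(-c3ccccc3)cc2-c2nc3cc(C(F)(F)F)ccc3[nH]2)cc1`, gives 2130 nM;
compound 3, `COc1ccc(-c2nn(-c3ccccc3)cc2-c2nc3cc(C(F)(F)F)ccc3[nH]2)cc1`, gives 5730 nM.

Compound 3 stands highest of the three in this assay, and its closest neighbour is compound 2: a 2.7-fold higher number from compound 2 to compound 3 (0.43 log units; beyond the scatter). The structural difference behind that step is methoxy in place of fluoro on an aromatic carbon. Compound 1 and compound 2 differ in another place, (methyl in place of trifluoromethyl on an aromatic carbon), and the step there is a 1.9-fold lower number from compound 2 to compound 1 (0.28 log units; within the scatter).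

Compound 4, `COc1ccc(-c2nn(-c3ccccc3)cc2-c2nc3cc(C)ccc3[nH]2)cc1`, has not yet been measured. It differs from compound 3 by methyl in place of trifluoromethyl on an aromatic carbon. This is the same change that separates compound 2 from compound 1, in the same surroundings, since the two place descriptions agree word for word. The two cores on which the change is made differ from one another by methoxy in place of fluoro on an aromatic carbon, a shift that on its own raised the number by a modest amount.

Among the compounds with values here, with only one earlier example of the change, the expectation for compound 4 rests on that single step: the methyl in place of trifluoromethyl went from compound 2 to compound 1 with a step that stayed within the usual scatter. Compound 4 is therefore expected to show a step of similar size, a 1.8-fold lower number from compound 3 to compound 4 (0.25 log units; within the scatter), in this assay. On that basis compound 4 is estimated at 3200 nM in this assay, with a likely range from 1500 nM to 7000 nM.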

Compound 4, half-maximal inhibitory concentration: 6610 nM
Compound 4: middle estimate off by 2.1-fold (0.32 log units), on the low side, and the stated range covers the measured number.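

In this assay, methyl in place of trifluoromethyl on the methoxy core gives a 1.2-fold higher number from compound 3 to compound 4 (0.06 log units; within the scatter), and this step agrees with the one seen on the fluoro core, so the two cores show no detectable difference in how they respond to this change: the same change on two cores in this assay, a 1.9-fold lower number (0.28 log units; within the scatter) from compound 2 to compound 1 and a 1.2-fold higher number (0.06 log units; within the scatter) from compound 3 to compound 4, 2.2-fold (0.34 log units) apart, within the scatter of two such steps. Methoxy in place of fluoro, now read on the methyl-bearing pair, gives a 5.9-fold higher number from compound 1 to compound 4 (0.77 log units; beyond the scatter), a step beyond the scatter that also agrees with its earlier counterpart on the trifluoromethyl-bearing pair: the same change on two cores in this assay, a 2.7-fold higher number (0.43 log units; beyond the scatter) from compound 2 to compound 3 and a 5.9-fold higher number (0.77 log units; beyond the scatter) from compound 1 to compound 4, 2.2-fold (0.34 log units) apart, within the scatter of two such steps. Together these results show that, for these four compounds, each change behaves alike on both cores, but with only two examples of each change they do not show that either would carry over to other cores or to other cell lines, nor do they explain why the steps take the sizes they do.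

The compounds shown leave open how other groups on the same aromatic carbon, such as chloro, a nitrile or an amine, would compare with methyl and trifluoromethyl. They also leave open whether a hydroxyl or a longer alkoxy chain in place of methoxy would move the number further than methoxy does.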